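Unsubstituted phenyl replaces dimethylphenyl on a sulfonamide scaffold

A few compounds are considered here, and "the series" means these few. Any claim that something is new, unique, unknown or untested is made for them only; others in the source may bear on it.

Of the compounds shown here, three sharing one core have been measured in a functional assay on DLD-1 cells (Homo sapiens) for antiproliferative activity, read by CellTiter-Glo, with a stated time of 72 h; a higher number here means a weaker inhibitor, a lower number a stronger inhibitor. Compound 1 `CC1CCN(C2CCN(S(=O)(=O)c3cccc(-c4ccccc4C(F)(F)F)c3)CC2)CC1` gives 10 nM. Compound 2 `CC1CCN(C2CCN(S(=O)(=O)c3cccc(Br)c3)CC2)CC1`, carrying a bromo in place of the aryl group, gives 3.2 nM. Compound 3 `Cc1cc(C)cc(-c2cccc(S(=O)(=O)N3CCC(N4CCC(C)CC4)CC3)c2)c1` gives 41 nM, the highest number of the three: a 4.1-fold higher number from compound 1 to compound 3 (0.61 log units; beyond the scatter) and a 13-fold higher number from compound 2 to compound 3 (1.11 log units; beyond the scatter).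

Compound 4 `CC1CCN(C2CCN(S(=O)(=O)c3cccc(-c4ccccc4)c3)CC2)CC1` differs from compound 3 in one place: phenyl in place of 3,5-dimethylphenyl on an aromatic carbon. The change keeps the aryl group on the aromatic carbon, meta to a large group, and only removes the two methyl groups.

Among the compounds with values here, the steps that bear on this are those leading into compound 3, both modest to large, and they show that the aryl substituent matters here. Since a 2-(trifluoromethyl)phenyl gave compound 1 a lower number than the dimethylphenyl of compound 3, a plain phenyl is expected to land between them, so a moderate fall is expected for compound 4, a 2.7-fold lower number from compound 3 to compound 4 (0.44 log units; beyond the scatter). Compound 4 is estimated at 15 nM, in the range 5 nM to 45 nM.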

Compound 4, half-maximal inhibitory concentration: 2 nM
Compound 4: middle estimate off by 7.5-fold (0.88 log units), on the high side; measured number outside the range, below it.
By their numbers in this assay, from the lowest: compounds 4 and 2 (each within the scatter of the next); then compound 1; then compound 3.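

In this assay, taking the two methyl groups off the 3,5-dimethylphenyl brings a large change (a 21-fold lower number from compound 3 to compound 4 (1.31 log units; beyond the scatter)), so the high number of compound 3 goes with those methyl groups and not with having an aryl group on this aromatic carbon at all. Plain phenyl and bromo cannot be told apart here (a 1.6-fold lower number from compound 2 to compound 4 (0.20 log units; within the scatter)), which shows that an unsubstituted aryl ring is as well accepted at this position as the small halogen, while the trifluoromethyl group also carries a cost (a 5.0-fold lower number from compound 1 to compound 4 (0.70 log units; beyond the scatter)). No measurement at hand explains any of these steps.

From the compounds shown here alone, whether a single methyl group on the phenyl would raise the number as well remains open. So does how a phenyl carrying an amine or a carboxylic acid would read in this assay.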